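The compounds below may be only part of what the source reports. "The series", "measured", "known", "first", "only" and "open" are said of these compounds alone.

Measured compounds:
- compound 1 `CC1CCN(C(=S)SCc2ccc(C(=O)Nc3ccccc3N)cc2)CC1`: in a functional assay on HeLa cells (Homo sapiens) for antiproliferative activity, read by CCK-8 assay, with a stated time of 72 h, tested at 2 uM (on this read-out higher numbers stand for a stronger effect at the one concentration tested and lower numbers for a weaker effect), compound 1 gives 46.8%
- compound 2 `CN(Cc1cccnc1)C(=S)SCc1ccc(C(=O)Nc2ccccc2N)cc1`: in this assay compound 2 gives 16.4%
- compound 3 `Nc1ccccc1NC(=O)c1ccc(CSC(=S)N2CCc3cc(Cl)ccc32)cc1`: in this assay compound 3 gives 40.1%

The three compounds share one core and differ only in the amine attached to the thiocarbonyl carbon. Compound 3 holds the second highest of the three numbers: its nearest neighbour is compound 1, with a gap that stays within the scatter, a number 6.7 percentage points lower from compound 1 to compound 3 (within the scatter), and its furthest is compound 2, a number 23.7 percentage points higher from compound 2 to compound 3 (beyond the scatter). The largest step of all is a number 30.4 percentage points lower from compound 1 to compound 2 (beyond the scatter).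

Compound 4 is `Nc1ccccc1NC(=O)c1ccc(CSC(=S)N2CCc3ccccc32)cc1`. It differs from compound 3 by hydrogen in place of chloro on an aromatic carbon, the 5-chloro-2,3-dihydro-1H-indol-1-yl becoming 2,3-dihydro-1H-indol-1-yl. Within the data shown here, none of the measured steps touches this position; each of them exchanges the whole amine on the thiocarbonyl carbon, and the pair that keeps the fused amine is the one that stays within the scatter. There is no evidence here that removing the chloro moves the number beyond the scatter. The step to compound 4 is therefore expected to be small, a number 4.1 percentage points lower from compound 3 to compound 4 (within the scatter). The estimate for compound 4 in this assay is 36%, with a range from 20% to 52%.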

Compound 4, a percentage reported as inhibition, at one concentration (the size of the read-out at that concentration, not a potency): 38%
The estimate for compound 4 lay 2 percentage points below the measured number, and the stated range covers the measured number.
By their numbers in this assay, from the lowest: compound 2; then compounds 4, 3 and 1 (each within the scatter of the next).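

In this assay, among these compounds, this is the first look at a change inside the fused amine rather than an exchange of the whole amine, and hydrogen in place of chloro on this aromatic carbon gives a number 2.1 percentage points lower from compound 3 to compound 4 (within the scatter) and no more, so at this one concentration the chloro is not required for the read-out. The 2,3-dihydro-1H-indol-1-yl without its chloro still separates from the methyl((pyridin-3-yl)methyl)amino group, with a number 21.6 percentage points higher from compound 2 to compound 4 (beyond the scatter) as the step, and it cannot be told apart from 4-methylpiperidin-1-yl, with a number 8.8 percentage points lower from compound 1 to compound 4 (within the scatter) as the step, so compound 3 and compound 4 both stand apart from compound 2 and level with compound 1. No measurement shown offers an explanation for how little this change does.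

Only chloro and hydrogen appear at this carbon, so a methoxy, a carboxylic acid or an amine there could still move the number beyond the scatter. A single concentration also gives the size of an effect and not a potency, so a real difference between compound 3 and compound 4 at other concentrations remains possible.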